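A few compounds are considered here, and "the series" means these few. Any claim that something is new, unique, unknown or untested is made for them only; others in the source may bear on it.

Of the compounds shown here, three built on one shared core have been measured in a functional assay on T47D cells (Homo sapiens) for inhibition, read by sulforhodamine B assay, with a stated time of 48 h; on this read-out higher numbers stand for weaker inhibition of growth and lower numbers for stronger inhibition of growth. Compound 1 `COC(=O)[C@@]1(C)CCC=C2[C@@H]1CC[C@@H](C)[C@]2(C)Cc1c[nH]c2ccc(Cl)cc12` gives 17000 nM. Compound 2 `COC(=O)[C@@]1(C)CCC=C2[C@@H]1CC[C@@H](C)[C@]2(C)Cc1c(C)[nH]c2ccc(C)cc12` gives 31000 nM, and compound 3 `COC(=O)[C@@]1(C)CCC=C2[C@@H]1CC[C@@H](C)[C@]2(C)Cc1c(C)[nH]c2ccc(Br)cc12` gives 16000 nM. Compound 3 carries the lowest number of the three, yet its gap to compound 1 and its gap to compound 2 both lie within the scatter of repeated measurements, so on this evidence no one of the three can be called the stronger inhibitor of growth. Among the compounds with values here, the only step between compounds differing in a single place, a 1.9-fold lower number from compound 2 to compound 3 (0.29 log units; within the scatter), also stays within that scatter.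

Compound 4 `COC(=O)[C@@]1(C)CCC=C2[C@@H]1CC[C@@H](C)[C@]2(C)Cc1c(C)[nH]c2ccc(Cl)cc12` has not yet been measured. It differs from compound 3 in one place: chloro in place of bromo on an aromatic carbon. Compound 1 carries a chloro at that same place, although it differs from compound 4 in a second place as well. Since compound 1 with its chloro gives 17000 nM while compound 3 with its bromo gives 16000 nM, two numbers within the scatter of each other, the swap is expected to change little. Compound 4 is therefore estimated to give 17000 nM, with a range from 8000 nM to 36000 nM. The step this estimate implies, a 1.1-fold higher number from compound 3 to compound 4 (0.03 log units; within the scatter), is expected to remain within the scatter.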

Compound 4, concentration for 50% growth inhibition: 17000 nM
Beside the measured number, compound 4's estimate shows no gap at the digits printed, and the stated range covers the measured number.
By their numbers in this assay, from the lowest: compounds 3, 1, 4 and 2 (each within the scatter of the next).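

In this assay this aromatic carbon has now been read with three groups on an otherwise identical compound: chloro in place of bromo brings a 1.1-fold higher number from compound 3 to compound 4 (0.03 log units; within the scatter) while chloro in place of methyl brings a 1.8-fold lower number from compound 2 to compound 4 (0.26 log units; within the scatter) and so no group at this place can be told from another. Before this result, only the step from methyl to bromo could be read here, and it left open whether chloro would behave any differently. A second place also comes into view, since methyl in place of hydrogen on an aromatic carbon of the shared core brings no change at the digits printed from compound 1 to compound 4 (within the scatter) and so shows no effect of that methyl with chloro present. No measurement at hand explains why these groups read alike.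

The compounds shown carry only bromo, chloro and methyl at the first place, so it remains open whether an amine, a carboxylic acid or a longer chain such as propyl there would move the number beyond the scatter. From the compounds shown here alone, at the second place only hydrogen and methyl appear, which leaves a longer chain such as ethyl equally open.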